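Methylating the amide nitrogen of compound 2

The source may report more compounds than this note shows. Statements on the series, on what has been measured and on what is new or still open speak of the compounds shown alone.

Measured so far:
Compound 1 `CNC(=O)c1ccc(-c2cnc3nnn(C(C)c4cc5cc(-c6cnn(C)c6)cnc5cc4F)c3n2)cc1F` gives 0.6 nM in a functional assay on SNU-5 cells (Homo sapiens) for inhibition, read by CCK-8 assay, with a stated time of 72 h; a higher number here means a weaker inhibitor, a lower number a stronger inhibitor.
Compound 2 `CC(c1c(F)cc2ncc(-c3cnn(C)c3)cc2c1F)n1nnc2ncc(-c3ccc(C(N)=O)c(F)c3)nc21` gives 0.4 nM in this assay.

The two numbers lie within the usual scatter of one another, with compound 2 sitting at the smaller end of the pair. Compound 3 `CNC(=O)c1ccc(-c2cnc3nnn(C(C)c4c(F)cc5ncc(-c6cnn(C)c6)cc5c4F)c3n2)cc1F` has not yet been measured. It differs from compound 2 in one place: methyl in place of hydrogen on an amide-type nitrogen. Compound 1 already carries a methylcarbamoyl group, but it also differs from compound 2 elsewhere, so its value only shows that a methylcarbamoyl compound and a carbamoyl compound both sit in the same narrow range of this assay. For the measured compounds named here, no measured pair isolates this change, so the step is expected to be a 1.3-fold higher number from compound 2 to compound 3 (0.10 log units; within the scatter), that is, nothing beyond the scatter in either direction. Compound 3 is therefore estimated at 0.5 nM, with a range from 0.2 nM to 1.5 nM.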

Compound 3, half-maximal inhibitory concentration: 0.9 nM
Compound 3: middle estimate off by 1.8-fold (0.26 log units), on the low side, and the stated range covers the measured number.
By their numbers in this assay, from the lowest: compounds 2, 1 and 3 (each within the scatter of the next, the first and the last beyond it).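

In this assay, methyl in place of hydrogen on the amide-type nitrogen can now be read on its own, and it gives a 2.3-fold higher number from compound 2 to compound 3 (0.35 log units; beyond the scatter), a modest step that lies just beyond the scatter. Fluoro in place of hydrogen on an aromatic carbon, read on the methylcarbamoyl series, gives a 1.5-fold higher number from compound 1 to compound 3 (0.18 log units; within the scatter), which stays within the scatter, so this pair shows no separable effect of that change. Nothing measured here accounts for the methyl step. The compounds shown leave open whether an ethyl group or a longer chain on this nitrogen, or a second methyl on it, would carry the trend further. They also leave open whether the methyl step would be the same size on the core of compound 1.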